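The source may hold more compounds than are shown below. What is called first, only, known or untested is meant among the compounds shown, and "the series" means these compounds.

Measured so far in a functional assay on SNB-75 cells (Homo sapiens) for inhibition, read by sulforhodamine B assay, with a stated time of 48 h; a higher number here means a weaker inhibitor of growth, a lower number a stronger inhibitor of growth:
compound 1 `COc1cc(-c2nn(-c3cccc(NC(=O)c4ccc(Cl)c(C(F)(F)F)c4)c3)cc2-c2ccncc2)ccc1Cl` gives 2190 nM
compound 2 `COc1cc(-c2nn(-c3cccc(NC(=O)c4cccc(C(F)(F)F)c4)c3)cc2-c2ccncc2)ccc1Cl` gives 1130 nM
compound 3 `O=C(Nc1cccc(-n2cc(-c3ccncc3)c(-c3ccc(Cl)c(O)c3)n2)c1)Nc1cc(C(F)(F)F)cc(C(F)(F)F)c1` gives 877 nM

In this assay the three numbers sit close together. Compound 2 is separated from compound 1 by a 1.9-fold lower number from compound 1 to compound 2 (0.29 log units; within the scatter), and the gap between compound 2 and compound 3 is also inside the scatter, so none of the three can be ranked against the others on these numbers.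

Compound 4 `COc1cc(-c2nn(-c3cccc(NC(=O)Nc4cccc(C(F)(F)F)c4)c3)cc2-c2ccncc2)ccc1Cl` is not yet measured. It is derived from compound 2 by (3-(trifluoromethyl)phenyl)amino in place of 3-(trifluoromethyl)phenyl on a carbonyl carbon. For the measured compounds named here, no measured step makes this same change on the shared core: the only step in hand, from compound 1 to compound 2, alters a different part of the molecule and was itself within the scatter. Compound 3 carries a urea of the same kind but differs from compound 2 in more than one place, so its value shows only that a urea on a related core lands in the same region as the amides.

On this basis the number for compound 4 is expected to stay near that of compound 2, with the estimated step from compound 2 to compound 4 being a 1.3-fold lower number from compound 2 to compound 4 (0.10 log units; within the scatter). The estimate for compound 4 in this assay is 900 nM, within the range 300 nM to 2700 nM.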

Compound 4, concentration for 50% growth inhibition: 1160 nM
For compound 4 the middle estimate is 1.3-fold (0.11 log units) below the measured one; the measured number falls inside the stated range.
By their numbers in this assay, from the lowest: compounds 3, 2, 4 and 1 (each within the scatter of the next, the first and the last beyond it).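

In this assay, replacing 3-(trifluoromethyl)phenyl with (3-(trifluoromethyl)phenyl)amino on the carbonyl carbon turns the amide of the shared core into a urea, and the read-out does not separate (a 1.0-fold higher number from compound 2 to compound 4 (0.01 log units; within the scatter)). This position therefore accepts the added nitrogen and its hydrogen-bond donor without a change that can be read in this assay, and the step that also removes the chloro group stays within the scatter as well (a 1.9-fold lower number from compound 1 to compound 4 (0.28 log units; within the scatter)). Nothing available bears on why the amide and urea read alike.

On these data alone, whether a longer chain or an aliphatic amine such as piperidine on this carbonyl carbon would separate from these values remains open. The same applies to a carboxylic acid on the terminal phenyl ring.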